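Sulfonate aryl swap: nitro to cyano on the ester aryl

This account rests on a few compounds, and the source may have more. Where it says the series, first, only, none or still open, it means among the compounds named here.

Compound 1 `O=C(c1ccc(Cl)c(C(F)(F)F)c1)N1CCC(n2cncc2-c2ccc(OS(=O)(=O)c3cccs3)cc2)CC1` and compound 2 `O=C(c1ccc(Cl)c(C(F)(F)F)c1)N1CCC(n2cncc2-c2ccc(OS(=O)(=O)c3cccc([N+](=O)[O-])c3)cc2)CC1` share a core and differ only in the sulfonyl aryl group. Going by the values given here, in an assay on HEK293 cells for antagonist activity at P2X purinoceptor 7 (Homo sapiens), read by fluorescence, with a stated time of 2 h (on this read-out lower numbers stand for stronger inhibition and higher numbers for weaker inhibition), compound 1 gives 238 nM, and compound 2 gives 249 nM; the step of a 1.0-fold higher number from compound 1 to compound 2 (0.02 log units; within the scatter) places compound 2 alongside compound 1 within the scatter, the only comparison available. Compound 3 `N#Cc1cccc(S(=O)(=O)Oc2ccc(-c3cncn3C3CCN(C(=O)c4ccc(Cl)c(C(F)(F)F)c4)CC3)cc2)c1` carries the change (cyano in place of nitro on an aromatic carbon). Among the compounds with values here, no measured step touches this exact exchange; the one sulfonyl aryl step was flat, so no movement beyond the scatter is expected, a 1.0-fold higher number from compound 2 to compound 3 (0.00 log units; within the scatter). Compound 3 is therefore estimated at 250 nM, between 120 nM and 520 nM.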

Compound 3, half-maximal inhibitory concentration: 73 nM
For compound 3 the middle estimate is 3.4-fold (0.53 log units) above the measured one; measured number below the stated range.
By their numbers in this assay, from the lowest: compound 3; then compounds 1 and 2 (each within the scatter of the next).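

In this assay cyano in place of nitro on the aromatic carbon gives a 3.4-fold lower number from compound 2 to compound 3 (0.53 log units; beyond the scatter) and 3-cyanophenyl in place of thiophen-2-yl gives a 3.3-fold lower number from compound 1 to compound 3 (0.51 log units; beyond the scatter) on the same sulfonyl sulfur. The sulfonyl aryl group can therefore move the number, which the flat step between compound 1 and compound 2 did not show. No measurement at hand accounts for this gain.

On these data alone, whether an amine or a carboxylic acid on this aromatic carbon would match the cyano group remains open. So does whether the cyano gain would carry over to a thiophen-2-yl sulfonate.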